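A few compounds are considered here, and "the series" means these few. Any claim that something is new, unique, unknown or untested is made for them only; others in the source may bear on it.

Within the data shown here, in an ADME assay on a cell-free system (plasma, Homo sapiens) for protein binding, with Plasma (Rattus norvegicus) as the target, compound 2 `Cc1cn(-c2ccc(Cn3cc(C(=O)O)c(=O)c4c(F)cccc43)cc2)cn1` gives 89.8%, and its only measured neighbour, compound 1 `O=C(O)c1cn(Cc2ccc(-n3ccnc3)cc2)c2cccc(F)c2c1=O`, gives 88.1%. These two values lie within the scatter of each other, so compound 2 stands level with compound 1 on the numbers available. Compound 3 `O=C(O)c1cn(Cc2ccc(-n3cnc4ccccc43)cc2)c2cccc(F)c2c1=O` differs from compound 2 in one place: 1H-benzimidazol-1-yl in place of 4-methyl-1H-imidazol-1-yl on an aromatic carbon. Here 1H-benzimidazol-1-yl stands in place of 4-methyl-1H-imidazol-1-yl on an aromatic carbon. Among the measured compounds shown here, the only measured step that bears on this swap is methyl in place of hydrogen on an aromatic carbon, a 1.2-fold lower unbound fraction from compound 1 to compound 2 (0.07 log units; within the scatter). That single small step is a thin guide to a different and larger group. The expectation is therefore only a slight move towards more binding, a 1.5-fold lower unbound fraction from compound 2 to compound 3 (0.16 log units; within the scatter), probably not beyond the scatter. For compound 3 the estimated value is 93%, with an expected range from 87% to 97%.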

Compound 3, plasma protein binding: 96.1%
Beside the measured number, compound 3's estimate is 1.8-fold (0.25 log units) (unbound fraction) above it; low and high end bracket the measured number.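

Replacing the group at this place with 1H-benzimidazol-1-yl gives a 2.6-fold lower unbound fraction from compound 2 to compound 3 (0.42 log units; beyond the scatter) and a 3.1-fold lower unbound fraction from compound 1 to compound 3 (0.48 log units; beyond the scatter) in this assay, so this position can respond to the group it carries. The methyl step, a 1.2-fold lower unbound fraction from compound 1 to compound 2 (0.07 log units; within the scatter), did not show this, while the change beyond the scatter adds a six-membered aromatic ring of carbon only and so brings more heavy atoms to the same aromatic carbon. Nothing given here explains why the unbound fraction falls with this change.

With so few groups compared, these compounds cannot separate the effect of the added ring from the effect of the larger group as a whole. From the compounds shown here alone, it also stays open whether a plain phenyl group or a morpholine at this place would bind more like compound 1 or more like compound 3.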